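From fluoro to hydroxy on an aromatic carbon

A few compounds are considered here, and "the series" means these few. Any claim that something is new, unique, unknown or untested is made for them only; others in the source may bear on it.

Measured so far in a functional assay on NCI/ADR-RES cells (Homo sapiens) for inhibition, read by sulforhodamine B assay, with a stated time of 48 h; on this read-out lower numbers stand for stronger inhibition of growth and higher numbers for weaker inhibition of growth
compound 1 `CC1(/C=C/c2ccccc2)C=CC(=O)O1` gives 414000 nM
compound 2 `CC1(/C=C/c2ccc(F)cc2)C=CC(=O)O1` gives 25700 nM

Of the two measured compounds, compound 2 stands lowest, with 25700 nM, and so shows the stronger inhibition of growth. The compound still to be measured is compound 3 `CC1(/C=C/c2ccc(O)cc2)C=CC(=O)O1`, which has hydroxy in place of fluoro on an aromatic carbon.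

For the measured compounds named here, only one measured step bears on this change. It is a 16-fold lower number from compound 1 to compound 2 (1.21 log units; beyond the scatter), large and beyond the scatter, with fluoro in place of hydrogen on an aromatic carbon. The fluoro group that entered in that step is the one that now leaves. Going by the values given here, no measured compound carries hydroxy, so the data do not show how it compares with hydrogen or fluoro. Part of the gain seen in a 16-fold lower number from compound 1 to compound 2 (1.21 log units; beyond the scatter) is therefore expected to be lost, giving a moderate move toward a higher number in this assay, though one smaller than that step. The expected step is a 2.7-fold higher number from compound 2 to compound 3 (0.44 log units; beyond the scatter). For compound 3 the estimate is 70000 nM, with an expected range from 20000 nM to 300000 nM.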

Compound 3, concentration for total growth inhibition: 111000 nM
Estimate against measurement, compound 3: 1.6-fold (0.20 log units) below; the measured number falls inside the stated range.
By their numbers in this assay, from the lowest: compound 2; then compound 3; then compound 1.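

For the compounds shown here, with hydroxy now on this aromatic carbon, this assay shows that fluoro is not the only group there that gives a lower number than hydrogen: hydroxy in place of hydrogen gives a 3.7-fold lower number from compound 1 to compound 3 (0.57 log units; beyond the scatter) and is beyond the scatter. Hydroxy in place of fluoro nevertheless gives a 4.3-fold higher number from compound 2 to compound 3 (0.64 log units; beyond the scatter) and so keeps only part of what fluoro gained, which shows that the two groups are not interchangeable at this position and places compound 3 between compound 2 and compound 1. No measurement is available here that would explain this order of the three compounds.

The compounds shown leave open where chloro, methoxy or an amine on this same aromatic carbon would fall relative to hydrogen, fluoro and hydroxy. They also leave open whether the same order would hold if the methyl group on the shared core gave way to a longer chain, or if a carboxylic acid stood in place of the hydroxy group.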